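Changing the aryl group on sulfur: forecast for compound 4

A few compounds are considered here, and "the series" means these few. Any claim that something is new, unique, unknown or untested is made for them only; others in the source may bear on it.

Compound 1 `Cc1ccc(SCc2ccc(C(=O)Nc3ccccc3N)cc2)cc1` gives 74.8% in a functional assay on HCT-116 cells (Homo sapiens) for inhibition, read by CCK-8 assay, with a stated time of 72 h, tested at 2 uM; on this read-out lower numbers stand for less inhibition of growth and higher numbers for more inhibition of growth at the one concentration tested.
Compound 2 `Nc1ccccc1NC(=O)c1ccc(CSc2cccc(F)c2)cc1` gives 5.5% in this assay.
Compound 3 `Cc1cc(C)cc(SCc2ccc(C(=O)Nc3ccccc3N)cc2)c1` gives 3.22% in this assay.

Compound 3 stands lowest of the three numbers; compound 2 lies within the scatter of it, while compound 1 sits far above, as a number 71.6 percentage points lower from compound 1 to compound 3 (beyond the scatter) shows. Compound 4 `CCc1ccc(SCc2ccc(C(=O)Nc3ccccc3N)cc2)cc1` is not yet measured and differs from compound 3 by 4-ethylphenyl in place of 3,5-dimethylphenyl on a sulfur. Among the measured compounds shown here, two measured steps bear on this change: a number 71.6 percentage points lower from compound 1 to compound 3 (beyond the scatter) was large, whereas a number 2.3 percentage points lower from compound 2 to compound 3 (within the scatter) was within the scatter. For the measured compounds named here, compound 4 carries a 4-ethylphenyl, which resembles the 4-methylphenyl of compound 1 more than the 3,5-dimethylphenyl of compound 3, so a rise in this assay is expected, though its size is uncertain because only the single step of a number 71.6 percentage points lower from compound 1 to compound 3 (beyond the scatter) supports it. Compound 4 is therefore estimated at 50%, within 10% to 80%, an expected step of a number 46.8 percentage points higher from compound 3 to compound 4 (beyond the scatter).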

Compound 4, percent growth inhibition at one concentration: 40.7%
For compound 4 the middle estimate is 9.3 percentage points above the measured one, within the range that was stated.
By their numbers in this assay, from the lowest: compounds 3 and 2 (each within the scatter of the next); then compound 4; then compound 1.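

In this assay the aryl group on sulfur keeps the same count of eight carbons, yet their arrangement matters: 4-ethylphenyl in place of 3,5-dimethylphenyl gives a clear rise (a number 37.5 percentage points higher from compound 3 to compound 4 (beyond the scatter)). 4-ethylphenyl also stands clear of 3-fluorophenyl (a number 35.2 percentage points higher from compound 2 to compound 4 (beyond the scatter)), but one added carbon on the 4-methylphenyl group brings a clear fall (a number 34.1 percentage points lower from compound 1 to compound 4 (beyond the scatter)). No measurement shown here explains these steps.

On these data alone, whether a propyl chain in place of the ethyl would continue this fall stays open, and so does the effect of an amine there.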